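The compounds below may be only part of what the source reports. "The series", "measured", "known", "first", "only" and "open" are said of these compounds alone.

Measured so far:
compound 1, `CC[C@@](C)(O)CC(=O)O[C@H](CC=C(C)C)C1=CC(=O)c2c(O)ccc(O)c2C1=O`, 12700 nM
compound 2, `CC(C)=CC[C@@H](OC(=O)CCO)C1=CC(=O)c2c(O)ccc(O)c2C1=O`, 55300 nM

Both numbers come from a functional assay on DU-145 cells (Homo sapiens) for cytotoxicity, read by MTT assay; a lower number here means a stronger inhibitor, a higher number a weaker inhibitor. Compound 2 stands at the highest of the two numbers in this assay; the nearest is compound 1, and the step of a 4.4-fold higher number from compound 1 to compound 2 (0.64 log units; beyond the scatter) is the only one available, with hydroxymethyl in place of 1-hydroxy-1-methylpropyl on a saturated chain carbon bound to a carbonyl carbon.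

Compound 3, `CCCCC(C)(O)CC(=O)O[C@H](CC=C(C)C)C1=CC(=O)c2c(O)ccc(O)c2C1=O`, is not yet measured. Its change from compound 2 is 1-hydroxy-1-methylpentyl in place of hydroxymethyl on a saturated chain carbon bound to a carbonyl carbon. Within the data shown here, this reverses the direction of the one measured step and enlarges the entering group, so a lower number in this assay is expected, of a size near that seen from compound 1 to compound 2, since nothing shows the longer chain behaving differently. The expected step is a 4.3-fold lower number from compound 2 to compound 3 (0.63 log units; beyond the scatter). Compound 3 is therefore estimated at 13000 nM, with a range of 4500 nM to 38000 nM.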

Compound 3, half-maximal inhibitory concentration: 76500 nM
Compound 3: the middle estimate sits 5.9-fold (0.77 log units) below what was measured; the measured number lies above the stated range.
By their numbers in this assay, from the lowest: compound 1; then compounds 2 and 3 (each within the scatter of the next).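

In this assay, enlarging the group on this saturated chain carbon bound to a carbonyl carbon does not move the number in one direction: a 1.4-fold higher number from compound 2 to compound 3 (0.14 log units; within the scatter), whereas a 6.0-fold higher number from compound 1 to compound 3 (0.78 log units; beyond the scatter). Among these three compounds, the lower number therefore belongs only to compound 1, with 1-hydroxy-1-methylpropyl, and neither the branched hydroxyl-bearing carbon nor the size of the entering group alone accounts for it, since compound 3 also carries that branched carbon and has the largest group. No measurement here gives a reason for this behaviour.

Going by these compounds, it remains open whether 1-hydroxy-1-methylbutyl would stay close to compound 1 or close to compound 3. The role of the hydroxyl is also unresolved, as every group compared here carries one, so a plain ethyl, an amine or a carboxylic acid at this place would test it.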